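This account rests on a few compounds, and the source may have more. Where it says the series, first, only, none or still open, it means among the compounds named here.

Measured compounds in an ADME assay on HepG2 cells (Homo sapiens) for cytotoxicity, read by CellTiter-Glo and resazurin assay, with a stated time of 72 h; on this read-out lower numbers stand for an effect already at smaller amounts and higher numbers for an effect only at larger amounts of compound:
Compound 1 `CC(C)N(Cc1cccc(OCCCCCC(=O)O)c1)C(=O)c1ccc(-c2cccc3ccccc23)cc1` gives > 26000 nM, which is a limit of the assay rather than a number.
Compound 2 `COc1cccc(-c2ccc(C(=O)N(Cc3cccc(OCCCCCC(=O)O)c3)C(C)C)cc2)c1` gives > 26000 nM, again a limit of the assay and not a number.

Among the measured compounds shown here, compound 2 therefore stands only at a limit in this assay, and the one further value shown, that of compound 1, is a limit as well. The step that the two limits leave unreadable from compound 1 to compound 2 cannot be read, since both ends sit at the limit; what can be said comes from the limit of > 26000 nM in this assay, at which 2 of the 2 values shown sit.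

Compound 3 `Cc1nnc(-c2cccc(-c3ccc(C(=O)N(Cc4cccc(OCCCCCC(=O)O)c4)C(C)C)cc3)c2)o1` has not yet been measured. It differs from compound 2 by 5-methyl-1,3,4-oxadiazol-2-yl in place of methoxy on an aromatic carbon. For the measured compounds named here, no measured step bears directly on this change; the only measured step is unreadable. The expectation for compound 3 can rest solely on the fact that both measured compounds sit at the limit, so a step that the limit leaves unreadable from compound 2 to compound 3 beyond the scatter is not expected in this assay. Compound 3 is thus estimated at 30000 nM, within a range from 12000 nM to 100000 nM.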

Compound 3, half-maximal effective concentration: > 26000 nM
Compound 3: only a limit was reported; the forecaster's own chance of this, stated with the estimate: 80%; the middle value does not contradict the limit.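

In this assay compound 3 gives > 26000 nM, which is a limit and not a number. The steps to compound 3 from compound 1 and from compound 2 therefore cannot be read: the limit of > 26000 nM in this assay, at which 3 of the 3 values shown sit. The compounds shown leave open whether compound 1, compound 2 and compound 3 differ at all in this assay.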